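Phenylpiperazine amides: shifting the chlorine around the ring

The source may report more compounds than this note shows. Statements on the series, on what has been measured and on what is new or still open speak of the compounds shown alone.

Compound 1 `CC(C)Cc1ccc(C(C)C(=O)NCc2ccccc2)cc1` carries a benzylamide and in an assay on brain for inhibition of Fatty-acid amide hydrolase 1 (Rattus norvegicus), read by scintillation counting, with a stated time of 10 min (on this read-out higher numbers stand for weaker inhibition and lower numbers for stronger inhibition), compound 1 gives 21000 nM. Compound 2 `CC(C)Cc1ccc(C(C)C(=O)N2CCN(c3ccccc3)CC2)cc1` replaces the benzylamine with a phenylpiperazine; in this assay compound 2 gives 4700 nM. Compound 3 `CC(C)Cc1ccc(C(C)C(=O)N2CCN(c3cccc(Cl)c3)CC2)cc1` adds a chlorine to that phenyl ring and gives 1700 nM in this assay. The single-point step is a 2.8-fold lower number from compound 2 to compound 3 (0.44 log units; beyond the scatter). Compound 3 thus holds the lowest number of the three, with compound 2 nearest and compound 1 furthest away.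

Compound 4 `CC(C)Cc1ccc(C(C)C(=O)N2CCN(c3ccc(Cl)cc3)CC2)cc1` is the next member: 4-chlorophenyl in place of 3-chlorophenyl on an amine nitrogen in a ring. Within the data shown here, no measured pair covers a move of the chlorine from one ring position to another, so only the chlorine-for-hydrogen step from compound 2 to compound 3 bears on it, and only indirectly: it shows that a chlorine on that ring is tolerated and lowers the number modestly, but says nothing about position. Among the measured compounds shown here, with no direct precedent, the expectation for compound 4 in this assay is a step of a 1.2-fold higher number from compound 3 to compound 4 (0.07 log units; within the scatter), i.e. no change beyond the scatter, with wide uncertainty either way. Compound 4 is therefore estimated at 2000 nM, with a range of 600 nM to 7000 nM.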

Compound 4, half-maximal inhibitory concentration: 1700 nM
Beside the measured number, compound 4's estimate is 1.2-fold (0.07 log units) above it, and the stated range covers the measured number.
By their numbers in this assay, from the lowest: compounds 3 and 4 (each within the scatter of the next); then compound 2; then compound 1.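

In this assay, among these compounds, the chlorine moves from the 3-chlorophenyl to the 4-chlorophenyl placement with no change at the digits printed from compound 3 to compound 4 (within the scatter), the first direct reading of chlorine position on this ring, and these two placements cannot be told apart. The chlorine-for-hydrogen step is thus not tied to a single placement, since there is a 2.8-fold lower number from compound 2 to compound 4 (0.44 log units; beyond the scatter), which matches in size the earlier 2.8-fold lower number from compound 2 to compound 3 (0.44 log units; beyond the scatter) and gives two chlorine-bearing compounds on the same footing against the unsubstituted phenylpiperazine. Nothing on hand speaks to why the two placements read alike.

Still open, on these data alone, is whether this indifference to position extends to the remaining ring positions, or holds only for chlorine and not for a fluorine, a methoxy, a trifluoromethyl or a carboxylic acid at the same places. Also open, as far as these compounds go, is whether two chlorines on the phenyl ring would go further in this assay than one, and whether a chlorine on the benzyl ring of compound 1 would give a step like the one seen on the phenylpiperazine.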